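Ethyl for tert-butoxycarbonyl on the anilide ring

The compounds below may be only part of what the source reports. "The series", "measured", "known", "first", "only" and "open" are said of these compounds alone.

Working notes on a small anilide series. Compound 1 `CC(C)(C)OC(=O)c1cccc(NC(=O)C2CCCN(C(=O)c3cc(C(F)(F)F)cc(C(F)(F)F)c3)C2)c1` gives 0% in an ADME assay on PC-3 cells (Homo sapiens) for cytotoxicity, read by WST assay, tested at 100 uM (a lower number here means less inhibition, a higher number more inhibition at the concentration tested (going by the name of the read-out)), level with compound 2 `O=C(Nc1ccc(Cl)cc1)C1CCCN(C(=O)c2cccc([N+](=O)[O-])c2)C1` at 0%, the two together the lowest of three numbers; compound 3 `CC(=O)Nc1cccc(C(=O)N2CCCC(C(=O)Nc3ccc(Cl)cc3)C2)c1` gives 4%. Within the data shown here, the one measured step, a number 4 percentage points higher from compound 2 to compound 3 (within the scatter), is within the scatter. Compound 4 `CCc1cccc(NC(=O)C2CCCN(C(=O)c3cc(C(F)(F)F)cc(C(F)(F)F)c3)C2)c1` differs from compound 1 in one place: ethyl in place of tert-butoxycarbonyl on an aromatic carbon. Among the measured compounds shown here, no measured step touches this change, and all three numbers sit close to zero, so nothing here points to a move beyond the scatter in either direction. The expectation for the step of a number 3 percentage points higher from compound 1 to compound 4 (within the scatter) is therefore no change beyond the scatter. Compound 4 is estimated at 3%, in the range 0% to 15%.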

Compound 4, a percentage reported as inhibition, at one concentration (the size of the read-out at that concentration, not a potency): 0%
Estimate against measurement, compound 4: 3 percentage points above, within the range that was stated.
By their numbers in this assay, from the lowest: compounds 1, 2, 4 and 3 (each within the scatter of the next).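

On the anilide ring, at the aromatic carbon meta to a large group, ethyl in place of tert-butoxycarbonyl gives no change at the digits printed from compound 1 to compound 4 (within the scatter) in this assay. Among these compounds, this is the first step read at this position, and it shows that this read-out does not separate the two groups, although tert-butoxycarbonyl is the larger and carries hydrogen-bond acceptors while ethyl carries none. No evidence bears on this result.

The compounds shown leave open whether any group at this carbon moves the number beyond the scatter. A carboxylic acid or an amine there could still read differently.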